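The source may hold more compounds than are shown below. What is called first, only, known or untested is meant among the compounds shown, and "the series" means these compounds.

Compound 1 `CC(C)Oc1nc(N)nc2ncc(-c3ccc(C#N)cc3)nc12` in a functional assay on cells (T-cell, Homo sapiens) for inhibition (a lower number here means a stronger inhibitor, a higher number a weaker inhibitor), gives > 10000 nM, which is a limit of the assay.
Compound 2 `COc1ccc(-c2cnc3nc(N)nc(N4CCN(C(=O)COc5ccccc5)CC4)c3n2)cc1OC` in this assay gives 4 nM.
Compound 3 `COc1ccc(-c2cnc3nc(N)nc(NC(C)C)c3n2)cc1OC` in this assay gives 600 nM.

Among the two compounds with a number in this assay, compound 2 holds the lower one, and the gap to compound 3 lies beyond the scatter of the method. Compound 1 sits at the limit of > 10000 nM in this assay, at which 1 of the 3 values shown sits, and therefore gives no number to compare. For the measured compounds named here, no pair of the measured compounds differs in a single place, so no measured step is available to guide the next change.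

Compound 4 `COc1ccc(-c2cnc3nc(N)nc(N4CCN(c5ccc(F)cc5)CC4)c3n2)cc1OC` keeps the shared core of compound 2 and changes only the group on the ring nitrogen: 4-fluorophenyl in place of (phenoxymethyl)carbonyl on an amine nitrogen in a ring. Going by the values given here, no measured step covers such a swap on an amine nitrogen in a ring, so the expectation rests on the standing of compound 2 alone. The step from compound 2 to compound 4 is expected to be a 3.8-fold higher number from compound 2 to compound 4 (0.57 log units; beyond the scatter), a modest move toward a higher number that may or may not clear the scatter. Compound 4 is therefore estimated at 15 nM in this assay, with a range from 3 nM to 100 nM.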

Compound 4, half-maximal inhibitory concentration: 100 nM
For compound 4 the middle estimate is 6.7-fold (0.82 log units) below the measured one, and the stated range covers the measured number.
By their numbers in this assay, from the lowest: compound 2; then compound 4; then compound 3. At a limit, above all of these: compound 1.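

In this assay, this step shows that the group on the amine nitrogen in a ring has a strong bearing on the number: 4-fluorophenyl in place of (phenoxymethyl)carbonyl gives a 25-fold higher number from compound 2 to compound 4 (1.40 log units; beyond the scatter). For the compounds shown here, the group that leaves and the group that enters each carry a six-membered aromatic ring of carbon only, so such a ring on this nitrogen does not alone set the number, although the single step changes the carbonyl, the chain and the fluorine together and cannot separate them. Nothing measured here accounts for the size of this step.

The compounds shown leave open whether the carbonyl on this nitrogen is what goes with the lower number, which a benzoyl or a plain acetyl group in the same place would help to settle, and whether the ether oxygen of the chain counts as well, as a 3-phenylpropanoyl group would show. They also leave open how far the fluorine matters, since an unsubstituted phenyl or a 4-methoxyphenyl group on the same nitrogen has no number among them.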